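Chain length and cytotoxicity in a sugar-sulfonate series

The source may report more compounds than this note shows. Statements on the series, on what has been measured and on what is new or still open speak of the compounds shown alone.

Measured compounds:
compound 1, `COC(=O)C(=O)CNC1=CS(=O)(=O)O[C@@]12[C@@H](CO[Si](C)(C)C(C)(C)C)O[C@@H](n1cc(C)c(=O)n(C)c1=O)[C@@H]2O[Si](C)(C)C(C)(C)C`, 5570 nM
compound 2, `Cc1cn([C@@H]2O[C@H](CO[Si](C)(C)C(C)(C)C)[C@@]3(OS(=O)(=O)C=C3NCCC(=O)O)[C@H]2O[Si](C)(C)C(C)(C)C)c(=O)n(C)c1=O`, 19400 nM
compound 3, `COC(=O)CNC1=CS(=O)(=O)O[C@@]12[C@@H](CO[Si](C)(C)C(C)(C)C)O[C@@H](n1cc(C)c(=O)n(C)c1=O)[C@@H]2O[Si](C)(C)C(C)(C)C`, 96000 nM

In a functional assay on CCRF-CEM cells (Homo sapiens) (on this read-out lower numbers stand for higher toxicity in this test and higher numbers for lower toxicity in this test), compound 3 gives the highest number of the three measured compounds. Its nearest neighbour is compound 2, with a 4.9-fold higher number from compound 2 to compound 3 (0.69 log units; beyond the scatter), and the furthest is compound 1, with a 17-fold higher number from compound 1 to compound 3 (1.24 log units; beyond the scatter). Compound 4, `COC(=O)CCNC1=CS(=O)(=O)O[C@@]12[C@@H](CO[Si](C)(C)C(C)(C)C)O[C@@H](n1cc(C)c(=O)n(C)c1=O)[C@@H]2O[Si](C)(C)C(C)(C)C`, differs from compound 3 in one place: (methoxycarbonyl)methyl in place of methoxycarbonyl on a saturated chain carbon bound to an amine nitrogen. Within the data shown here, the steps that bear on this change are those that alter the same chain on the amine nitrogen, a 3.5-fold higher number from compound 1 to compound 2 (0.54 log units; beyond the scatter) and a 4.9-fold higher number from compound 2 to compound 3 (0.69 log units; beyond the scatter); both are modest, and the larger step of a 17-fold higher number from compound 1 to compound 3 (1.24 log units; beyond the scatter) arises where the chain is changed more deeply. Adding one chain carbon is therefore expected to give a modest step, most likely towards a lower number, since compound 2, which carries a chain of matching length, shows 19400 nM. For compound 4 the estimate is 40000 nM, within 10000 nM to 150000 nM, which means a 2.4-fold lower number from compound 3 to compound 4 (0.38 log units; beyond the scatter).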

Compound 4, half-maximal cytotoxic concentration: > 250000 nM
Compound 4: a limit, no number; the forecaster's own chance of this, stated with the estimate: 15%; middle value at least 6.2-fold (0.79 log units) away from the limit.
By their numbers in this assay, from the lowest: compound 1; then compound 2; then compound 3. At a limit, above all of these: compound 4.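

In this assay compound 4 gives no number, only a limit: the limit of > 250000 nM in this assay, at which 1 of the 4 values shown sits.

Going from (methoxycarbonyl)methyl to 2-(methoxycarbonyl)ethyl gives an at least 2.6-fold higher number from compound 3 to compound 4 (0.41 log units; beyond the scatter), so this longer ester chain does not bring the number down towards the acid of matching length, and toxicity in this test falls rather than rises. On the same chain, the methyl ester differs sharply from the free acid, with an at least 12-fold higher number from compound 2 to compound 4 (1.11 log units; beyond the scatter), and replacing the (methoxycarbonyl)carbonyl group with (methoxycarbonyl)methyl gives an at least 44-fold higher number from compound 1 to compound 4 (1.65 log units; beyond the scatter), the widest step seen at this place on the amine nitrogen.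

As far as these compounds go, whether a still longer chain, or an amide or an amine at the end of the chain, would keep the number this high remains open. The compounds shown also do not tell why changes at this place move the number so far.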